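Replacing the pyridine ring on compound 3 with a cyanophenyl group

The compounds below may be only part of what the source reports. "The series", "measured", "known", "first", "only" and "open" are said of these compounds alone.

The compounds measured so far, with their inhibition in a functional assay on Bel-7402 cells (Homo sapiens) for inhibition, read by sulforhodamine B assay, with a stated time of 72 h, tested at 10 uM; on this read-out lower numbers stand for less inhibition and higher numbers for more inhibition at the one concentration tested (going by the name of the read-out):
compound 1, `C[C@H](Nc1ncnc2[nH]cnc12)c1nn(-c2cccc(F)c2)c2cc(F)ccc12`: -17%
compound 2, `C[C@H](Nc1nc(N)nc2[nH]cnc12)c1nn(-c2cccnc2)c2cc(F)ccc12`: -5%
compound 3, `C[C@H](Nc1ncnc2[nH]cnc12)c1nn(-c2cccnc2)c2cc(F)ccc12`: 8%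

Compound 3 gives the highest number of the three; compound 2 sits lower by a number 13 percentage points higher from compound 2 to compound 3 (beyond the scatter) and compound 1 lower still by a number 25 percentage points higher from compound 1 to compound 3 (beyond the scatter), both steps beyond the scatter. Compound 4, `C[C@H](Nc1ncnc2[nH]cnc12)c1nn(-c2ccc(C#N)cc2)c2cc(F)ccc12`, has not yet been measured. It differs from compound 3 at the aromatic nitrogen of the shared core: 4-cyanophenyl in place of pyridin-3-yl on an aromatic nitrogen

Among the compounds with values here, only one measured step touches this position, the move from a six-membered carbon-only ring to pyridin-3-yl, a number 25 percentage points higher from compound 1 to compound 3 (beyond the scatter), which went upward. Compound 4 returns to a carbon-only ring, though with nitrile in place of fluorine, so the earlier step is not a direct mirror. A downward shift from compound 3 is therefore expected, of about a number 13 percentage points lower from compound 3 to compound 4 (beyond the scatter), with wide uncertainty. Compound 4 is estimated at -5% in this assay, in a range from -25% to 15%.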

Compound 4, a percentage reported as inhibition, at one concentration (the size of the read-out at that concentration, not a potency): 0%
For compound 4 the middle estimate is 5 percentage points below the measured one; the range from low to high includes it.
By their numbers in this assay, from the lowest: compound 1; then compounds 2, 4 and 3 (each within the scatter of the next, the first and the last beyond it).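

In this position, putting 4-cyanophenyl in place of pyridin-3-yl gives a number 8 percentage points lower from compound 3 to compound 4 (within the scatter) in this assay and so shows that a ring nitrogen is not needed to stay within the scatter of the pyridine compound. The earlier compounds shown here could not show this, since their only carbon-only ring was 3-fluorophenyl, and the change to 4-cyanophenyl gives a number 17 percentage points higher from compound 1 to compound 4 (beyond the scatter), so two carbon-only rings on this aromatic nitrogen read differently. No measurement in hand accounts for the gap between these two rings.

The compounds shown vary this ring only among 3-fluorophenyl, pyridin-3-yl and 4-cyanophenyl, so what an amine or a carboxylic acid on the ring would do remains open. Going by these compounds, it also remains open whether the amino group of compound 2 would act the same way on a 4-cyanophenyl compound.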